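Sulfonyl anilide series: pyrazinyl in place of methoxyphenyl

The source may hold more compounds than are shown below. What is called first, only, known or untested is meant among the compounds shown, and "the series" means these compounds.

Working notes on three measured compounds and one awaiting measurement. Compound 1 `CC(O)(C(=O)Nc1ccc(C#N)c(Sc2ccccc2)c1)C(F)(F)F` gives 8300 nM in a functional assay (Cavia porcellus) with sulfonylurea receptors; K-ATP channels (Homo sapiens) as the target; a lower number here means a stronger inhibitor, a higher number a weaker inhibitor. Compound 2 `COc1cc(NC(=O)C(C)(O)C(F)(F)F)ccc1S(=O)(=O)c1ccccc1` gives 5900 nM in this assay. Compound 3 `COc1ccc(S(=O)(=O)c2ccc(NC(=O)C(C)(O)C(F)(F)F)cc2)cc1` returns only a limit in this assay, namely > 30000 nM, so no number is known for it. Among the three values shown, compound 3 stands at the limit of > 30000 nM in this assay, at which 1 of the 3 values shown sits, the weak end of what the measurement resolves, while compound 1 and compound 2 lie within the scatter of each other and give no order between them.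

The next compound, compound 4 `CC(O)(C(=O)Nc1ccc(S(=O)(=O)c2cnccn2)cc1)C(F)(F)F`, differs from compound 3 in one place: pyrazin-2-yl in place of 4-methoxyphenyl on a sulfonyl sulfur. Among the compounds with values here, no step between measured compounds exists to anchor the size of this change. With compound 3 sitting at the limit of > 30000 nM in this assay, at which 1 of the 3 values shown sits, the expected step of an at least 1.5-fold lower number from compound 3 to compound 4 (0.17 log units; that floor lies within the scatter) is modest and, if anything, toward a stronger inhibitor, though a second limit remains quite possible. Compound 4 is estimated at 20000 nM in this assay, with a range from 5000 nM to 60000 nM.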

Compound 4, half-maximal inhibitory concentration: 12000 nM
For compound 4 the middle estimate is 1.7-fold (0.22 log units) above the measured one, within the range that was stated.
By their numbers in this assay, from the lowest: compounds 2, 1 and 4 (each within the scatter of the next, the first and the last beyond it). At a limit, above all of these: compound 3.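

In this assay, the position on the sulfonyl sulfur now has a readable step, the first in this series: pyrazin-2-yl in place of 4-methoxyphenyl gives an at least 2.5-fold lower number from compound 3 to compound 4 (0.39 log units; beyond the scatter). The position therefore responds to what is attached there, and this change moves the series from a limit to a measured number. The true size of the step remains unknown and only its floor can be read, because compound 3 stands at a limit: the limit of > 30000 nM in this assay, at which 1 of the 4 values shown sits.

The methoxy group and the ring carbon atoms change together in this step, and the compounds shown do not separate the two contributions. Also open, as far as these compounds go, is how a pyridin-2-yl group on the same sulfur would stand, or a pyrazin-2-yl group carrying an amine.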